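The source may hold more compounds than are shown below. What is called first, only, known or untested is meant among the compounds shown, and "the series" means these compounds.

The series rests on two fused cores that carry the same side chains. Compound 1 `Cc1cc(-n2ccc3cccnc32)cn2c(CSCCc3ccccc3)cnc12` and compound 2 `Cc1cc(C#N)cn2c(CSCCc3ccccc3)cnc12` share the first core, and compound 3 `Cc1cc(-n2ccc3cccnc32)c2ncc(CSCCc3ccccc3)n2c1` and compound 4 `Cc1cc(C#N)c2ncc(CSCCc3ccccc3)n2c1` share the second; the difference between the two cores is not broken down here. In an ADME assay on HEL cells (Homo sapiens) for cytotoxicity, with a stated time of 3 days (a higher number here means that more compound is tolerated, a lower number that less compound is tolerated), compound 1 gives 16 ug/mL. In this assay compound 2 gives 14 ug/mL. The change a group of 2 heavy atoms (1 carbon, 1 nitrogen; no ring) in place of a group of 9 heavy atoms (7 carbon, 2 nitrogen; one five-membered aromatic ring with 1 hetero atom, one six-membered aromatic ring with 1 hetero atom), on an aromatic carbon therefore made a 1.1-fold lower number from compound 1 to compound 2 (0.06 log units; within the scatter) on the first core. For compound 3 the result in this assay is a limit of the assay, > 100 ug/mL. This is the limit of > 100 ug/mL in this assay, at which 1 of the 3 values shown sits. Compound 4 carries the same kind of change on the second core, (a group of 2 heavy atoms (1 carbon, 1 nitrogen; no ring) in place of a group of 9 heavy atoms (7 carbon, 2 nitrogen; one five-membered aromatic ring with 1 hetero atom, one six-membered aromatic ring with 1 hetero atom), on an aromatic carbon); the two places are not the same, in that the site on the first core is para to a fused ring, whereas on the second core it is ortho to a fused ring.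

Compound 4 is not yet measured. Because the same kind of change gave a 1.1-fold lower number from compound 1 to compound 2 (0.06 log units; within the scatter) on the first core, compound 4 is expected to stay close to compound 3. Because compound 3 sits at the limit of > 100 ug/mL in this assay, at which 1 of the 3 values shown sits, the number expected for compound 4 lies near that limit, and a second limit rather than a number is a real possibility. For compound 4 the estimate in this assay is 100 ug/mL, with a range from 45 ug/mL to 220 ug/mL. For compound 4 this estimate means an expected step of a number no higher from compound 3 to compound 4 (the limit leaves the size open).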

Compound 4, half-maximal cytotoxic concentration: > 100 ug/mL
Compound 4 was reported as a limit; the forecaster's own chance of this, stated with the estimate: 60%; the middle value lies on the limit itself.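

In this assay compound 4 is reported only as a limit of the assay, as is compound 3, so no step between the two can be read: the limit of > 100 ug/mL in this assay, at which 2 of the 4 values shown sit.

The compounds shown leave open how compound 3 and compound 4 compare as actual numbers, and so whether the change to cyano on the core of compound 3 behaves as it does on the core of compound 1.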